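A few compounds are considered here, and "the series" means these few. Any claim that something is new, unique, unknown or untested is made for them only; others in the source may bear on it.

In a functional assay on HCT-116 cells (Homo sapiens) for antiproliferative activity, read by MTT assay, with a stated time of 48 h (a higher number here means a weaker inhibitor, a lower number a stronger inhibitor), compound 2 `CCCCCCC(CCO)n1cnc2c(NC)ncnc21` gives > 50000 nM, which is a limit and not a number. Compound 3 `CCCCCCC(CCO)n1cnc2c(N(C)C)ncnc21` gives > 50000 nM, again a limit. Compound 1 `CCCCCCC(CCO)n1cnc2c(Cl)ncnc21` gives 11900 nM, and replacing its chloro group gave an at least 4.2-fold higher number from compound 1 to compound 2 (0.62 log units; beyond the scatter) and an at least 4.2-fold higher number from compound 1 to compound 3 (0.62 log units; beyond the scatter). Compound 4 `CCCCCCCCCCCC(CCO)n1cnc2c(NC)ncnc21` keeps the methylamino group of compound 2 but extends the chain: pentyl in place of hydrogen on a saturated chain carbon, seven bonds along the chain from an aromatic nitrogen. Neither measured step touches that chain, so neither sets a size for this change. Since compound 1 gave a number at 11900 nM, a readable value on this core is possible. A modest move toward stronger inhibition is therefore expected, an estimated at least 2.0-fold lower number from compound 2 to compound 4 (0.30 log units; that floor lies within the scatter). Compound 4 is estimated at 25000 nM, with an expected range of 8000 nM to 70000 nM.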

Compound 4, half-maximal inhibitory concentration: 15400 nM
Compound 4: middle estimate off by 1.6-fold (0.21 log units), on the high side, and the stated range covers the measured number.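

In this assay, extending the chain gives an at least 3.2-fold lower number from compound 2 to compound 4 (0.51 log units; beyond the scatter), so a readable value appears with the methylamino group kept in place. Going by these compounds alone, the earlier steps left the chain untouched, so this is the first sign that a change at this position alone can move the result beyond the scatter. The true size stays open because compound 2 carries a limit and not a number: the limit of > 50000 nM in this assay, at which 2 of the 4 values shown sit.

From the compounds shown here alone, whether a still longer chain, or one ending in an amine, would go further remains open. So does whether adding pentyl would do the same with the chloro group of compound 1.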